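From amino to diethylamino on the amide side chain

The source may hold more compounds than are shown below. What is called first, only, known or untested is meant among the compounds shown, and "the series" means these compounds.

Measured in a functional assay on PC-3 cells (Homo sapiens) for antiproliferative activity, read by MTT assay, with a stated time of 24 h; a higher number here means a weaker inhibitor, a lower number a stronger inhibitor:
Compound 1 `CCn1c(C(=O)NCC(=O)OC)ccc1C(CC)(CC)c1ccc(OCS(=O)(=O)c2ccccc2)c(C)c1`: > 50000 nM, a limit of the assay
Compound 2 `CCn1c(C(=O)NCCC(=O)OC)ccc1C(CC)(CC)c1ccc(OCS(=O)(=O)c2ccccc2)c(C)c1`: 40400 nM
Compound 3 `CCn1c(C(=O)NCCN)ccc1C(CC)(CC)c1ccc(OCS(=O)(=O)c2ccccc2)c(C)c1`: 6890 nM

Compound 3 has the lower of the two actual numbers, and compound 2 is its nearest neighbour. Two measured steps lead to compound 3: a 5.9-fold lower number from compound 2 to compound 3 (0.77 log units; beyond the scatter), and an at least 7.2-fold lower number from compound 1 to compound 3 (0.86 log units; beyond the scatter). The second is only a floor, given (the limit of > 50000 nM in this assay, at which 1 of the 3 values shown sits).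

Compound 4 `CCN(CC)CCNC(=O)c1ccc(C(CC)(CC)c2ccc(OCS(=O)(=O)c3ccccc3)c(C)c2)n1CC` keeps the shared core and alters only the chain end: diethylamino in place of amino on a saturated chain carbon, two bonds along the chain from an amide-type nitrogen. This places diethylamino in place of amino on a saturated chain carbon, two bonds along the chain from an amide-type nitrogen. Among the measured compounds shown here, both measured steps replace a methoxycarbonyl end, and no measured compound carries diethylamino, so neither step sizes this change directly. In this assay, no shift beyond the scatter is therefore expected, though the uncertainty runs in both directions. The expected change is a 1.1-fold lower number from compound 3 to compound 4 (0.06 log units; within the scatter). Compound 4 is expected at 6000 nM, with an estimated range of 1800 nM to 20000 nM.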

Compound 4, half-maximal inhibitory concentration: 7130 nM
Compound 4: middle estimate off by 1.2-fold (0.07 log units), on the low side; measured number inside the range.
By their numbers in this assay, from the lowest: compounds 3 and 4 (each within the scatter of the next); then compound 2. At a limit, above all of these: compound 1.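

In this assay, the end of the chain takes diethylamino, with its 5 heavy atoms and no hydrogen-bond donor, in place of amino with no shift beyond the scatter (a 1.0-fold higher number from compound 3 to compound 4 (0.01 log units; within the scatter)). Compound 4 also stands clear of the ester compound 2 (a 5.7-fold lower number from compound 2 to compound 4 (0.75 log units; beyond the scatter)), so both amine-ended compounds now share this separation, and the amide-side end tolerates substitution on that nitrogen. The step from compound 1 (an at least 7.0-fold lower number from compound 1 to compound 4 (0.84 log units; beyond the scatter)) is only a floor, set by a limit of the assay: (the limit of > 50000 nM in this assay, at which 1 of the 4 values shown sits).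

The compounds shown leave open whether a monoethylamino end, or a ring amine such as piperidine or morpholine, would keep this level. On these data alone, it also remains open how a carboxylic acid end or a longer chain before the amine would read in this assay.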